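One added methyl on the ethyl group of compound 2

A few compounds are considered here, and "the series" means these few. Any claim that something is new, unique, unknown or untested is made for them only; others in the source may bear on it.

Measured in a functional assay on MDA-MB-231 cells (Homo sapiens) for inhibition, read by CCK-8 assay, with a stated time of 48 h; on this read-out higher numbers stand for weaker inhibition of growth and lower numbers for stronger inhibition of growth:
compound 1 `CN1CCN(c2ccc(Nc3ncc(Cl)c(NCc4ccc(C(F)(F)F)cc4)n3)nc2)CC1` gives 19100 nM
compound 2 `CCc1ccc(Nc2nc(Nc3ccc(N4CCN(C)CC4)cn3)ncc2Cl)cc1` gives 5560 nM

Compound 2 has the lower number of the two, with 5560 nM against the higher one of compound 1. Compound 3 `CC(C)c1ccc(Nc2nc(Nc3ccc(N4CCN(C)CC4)cn3)ncc2Cl)cc1` differs from it by methyl in place of hydrogen on a saturated chain carbon bound to an aromatic carbon and a saturated chain carbon on the ethyl group, which becomes isopropyl. For the measured compounds named here, the only measured step is a 3.4-fold lower number from compound 1 to compound 2 (0.54 log units; beyond the scatter) and it exchanged a whole group, so it bears only loosely on a change this small. In this assay no step beyond the scatter is therefore expected. The expected change is a 1.1-fold lower number from compound 2 to compound 3 (0.05 log units; within the scatter) in this estimate. Compound 3 is expected at 5000 nM with 2300 nM to 11000 nM as the estimated range.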

Compound 3, concentration for 50% growth inhibition: 7020 nM
Compound 3: middle estimate off by 1.4-fold (0.15 log units), on the low side; low and high end bracket the measured number.
By their numbers in this assay, from the lowest: compounds 2 and 3 (each within the scatter of the next); then compound 1.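

In this assay, the added methyl gives a 1.3-fold higher number from compound 2 to compound 3 (0.10 log units; within the scatter), so turning ethyl into isopropyl at this position leaves the read-out within the scatter. The 4-isopropylphenyl group also stays clear of the 4-(trifluoromethyl)benzyl group, with a 2.7-fold lower number from compound 1 to compound 3 (0.43 log units; beyond the scatter), so the earlier gain from the exchange of the whole group survives this added carbon. No measurement at hand explains either step. The compounds shown leave open whether a tert-butyl group, a longer chain such as n-butyl, or an amine at this position would move the number beyond the scatter.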